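Replacing Methoxy with Benzoyl: Expected Growth Inhibition

This account rests on a few compounds, and the source may have more. Where it says the series, first, only, none or still open, it means among the compounds named here.

Three measured compounds share one core and differ only in the substituted phenyl group carried on an aromatic nitrogen. In a functional assay on MIA PaCa-2 cells (Homo sapiens) for inhibition, read by MTT assay, with a stated time of 72 h, tested at 50 uM (a lower number here means less inhibition of growth, a higher number more inhibition of growth at the concentration tested), compound 1 `C=CCc1ccc(OCc2cn(-c3ccc(C#N)cc3)nn2)c(O)c1` gives 45.9%. Compound 2 `C=CCc1ccc(OCc2cn(-c3ccccc3Cl)nn2)c(O)c1` gives 57.7% in this assay, and compound 3 `C=CCc1ccc(OCc2cn(-c3ccc(OC)cc3)nn2)c(O)c1` gives 88.2%. Compound 3 therefore stands highest of the three: the step of a number 42.3 percentage points higher from compound 1 to compound 3 (beyond the scatter) and the step of a number 30.5 percentage points higher from compound 2 to compound 3 (beyond the scatter) both lie beyond the scatter, as does the smaller step of a number 11.8 percentage points higher from compound 1 to compound 2 (beyond the scatter). Compound 4 `C=CCc1ccc(OCc2cn(-c3ccc(C(=O)c4ccccc4)cc3)nn2)c(O)c1` differs from compound 3 by benzoyl in place of methoxy on an aromatic carbon. Among the compounds with values here, no measured step leads to benzoyl, so the only guide is that changing the group on this ring has shifted the number by large amounts, and that the group now leaving is the one that accompanied the highest number. A move back toward the values of compound 1 and compound 2 is expected, with wide uncertainty, so a number 33.2 percentage points lower from compound 3 to compound 4 (beyond the scatter) is estimated. Compound 4 is expected to give about 55% in this assay, within a range of 30% to 85%.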

Compound 4, percent growth inhibition at one concentration: 53.7%
Estimate against measurement, compound 4: 1.3 percentage points above; the range from low to high includes it.
By their numbers in this assay, from the lowest: compounds 1, 4 and 2 (each within the scatter of the next, the first and the last beyond it); then compound 3.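

Benzoyl, with its added six-membered aromatic ring, gives a number 34.5 percentage points lower from compound 3 to compound 4 (beyond the scatter) in this assay, so a much bigger group at this place does not keep the high number that goes with methoxy. Benzoyl in place of cyano gives a number 7.8 percentage points higher from compound 1 to compound 4 (within the scatter) in this assay, which means these two groups cannot be told apart here, and among the three compounds carrying a group at this place, methoxy alone stands out. Nothing available says why methoxy differs from the other two groups.

The compounds shown leave open whether the high number needs the oxygen of methoxy or only a group of about its size. Ethoxy, hydroxy, methyl or a dimethylamino group at this same place would begin to separate those possibilities.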